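Adding a Bromo Group to Compound 2

A few compounds are considered here, and "the series" means these few. Any claim that something is new, unique, unknown or untested is made for them only; others in the source may bear on it.

Measured in a functional assay on T47D cells (Homo sapiens) for cytotoxicity, read by MTT assay, with a stated time of 48 h; on this read-out lower numbers stand for stronger inhibition and higher numbers for weaker inhibition:
Compound 1 `Fc1ccc(NC(=S)N/N=C\c2ccnc3ccccc23)cc1`: 1070 nM
Compound 2 `S=C(N/N=C\c1ccnc2ccccc12)Nc1ccccc1`: 1380 nM

Among the compounds with values here, compound 2, at 1380 nM, stands within the scatter of compound 1, the only other measured compound. The next compound to be tested in this assay is compound 3 `S=C(N/N=C\c1ccnc2ccccc12)Nc1ccc(Br)cc1`, which carries bromo in place of hydrogen on an aromatic carbon, para to a large group (bromo in place of hydrogen on an aromatic carbon). Within the data shown here, one measured step bears on this change, a swap of hydrogen in place of fluoro on an aromatic carbon: a 1.3-fold higher number from compound 1 to compound 2 (0.11 log units; within the scatter). Among the measured compounds shown here, no bromo compound has been measured, so this single small step is the only guide. On that basis, no step beyond the scatter is expected, and the estimated change is a 1.3-fold lower number from compound 2 to compound 3 (0.10 log units; within the scatter). The estimate for compound 3 is 1100 nM, with an expected range from 500 nM to 2400 nM.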

Compound 3, half-maximal inhibitory concentration: 1480 nM
Compound 3: the middle estimate sits 1.3-fold (0.13 log units) below what was measured; low and high end bracket the measured number.
By their numbers in this assay, from the lowest: compounds 1, 2 and 3 (each within the scatter of the next).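

In this assay the change from phenyl to 4-bromophenyl, on the aromatic carbon para to a large group, does not separate bromo from hydrogen (a 1.1-fold higher number from compound 2 to compound 3 (0.03 log units; within the scatter)). Bromo and fluoro at this place are not separated either (a 1.4-fold higher number from compound 1 to compound 3 (0.14 log units; within the scatter)), so hydrogen, fluoro and bromo now all lie within the scatter of one another, where the earlier compounds offered only the single comparison of hydrogen with fluoro. No evidence is at hand that could explain this flat reading.

Going by these compounds, whether a group of another kind at this place, such as an amine, a carboxylic acid or a longer chain, would give a step beyond the scatter remains open. Also open, on these data alone, is whether bromo on another carbon of this ring would read the same.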